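Fluoro-to-methoxy swap on the benzothiazole of a pyrrole-biaryl series

The source may hold more compounds than are shown below. What is called first, only, known or untested is meant among the compounds shown, and "the series" means these compounds.

Measured compounds:
compound 1 `Cc1ccc(-c2ccc(C)n2-c2ccc(-c3nc4ccc(F)cc4s3)cc2)cc1`, 3140 nM
compound 2 `COc1cc(-c2ccc(C)n2-c2ccc(-c3nc4ccc(F)cc4s3)cc2)cc(OC)c1OC`, 3000 nM
compound 3 `COc1ccc2nc(-c3ccc(-n4c(C)ccc4-c4ccc(C)cc4)cc3)sc2c1`, 4010 nM

In a functional assay on MDA-MB-231 cells (Homo sapiens) for cytotoxicity, read by sulforhodamine B assay, with a stated time of 48 h (a higher number here means a weaker inhibitor of growth, a lower number a stronger inhibitor of growth), compound 1 gives 3140 nM, compound 2 gives 3000 nM and compound 3 gives 4010 nM. All three numbers sit within the scatter of one another, so no order among them can be read. The difference between compound 1 and compound 2 is not broken down here. Compound 3 differs from compound 1 by methoxy in place of fluoro on an aromatic carbon, and that change produced a 1.3-fold higher number from compound 1 to compound 3 (0.11 log units; within the scatter).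

Compound 4 `COc1ccc2nc(-c3ccc(-n4c(C)ccc4-c4cc(OC)c(OC)c(OC)c4)cc3)sc2c1` is not yet measured. Among the compounds with values here, it differs from compound 2 by methoxy in place of fluoro on an aromatic carbon, the same change as the one from compound 1 to compound 3, at the same place. On the strength of that single precedent, the expected step is a 1.3-fold higher number from compound 2 to compound 4 (0.10 log units; within the scatter) in this assay, which rests only on the step from compound 1 to compound 3. Compound 4 is therefore estimated at 3800 nM, expected to fall between 2200 nM and 6500 nM.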

Compound 4, concentration for 50% growth inhibition: 1760 nM
Estimate against measurement, compound 4: 2.2-fold (0.33 log units) above; the whole stated range lies above it.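

In this assay, replacing 6-fluoro-1,3-benzothiazol-2-yl with 6-methoxy-1,3-benzothiazol-2-yl gives a 1.7-fold lower number from compound 2 to compound 4 (0.23 log units; within the scatter), so on this second core the change again stays within the scatter. The two steps point in opposite directions on paper, but the gap between them does not exceed what repeated measurement allows: the same change on two cores in this assay, a 1.3-fold higher number (0.11 log units; within the scatter) from compound 1 to compound 3 and a 1.7-fold lower number (0.23 log units; within the scatter) from compound 2 to compound 4, 2.2-fold (0.34 log units) apart, within the scatter of two such steps. The change therefore carries across these two cores without a readable effect on either; this does not show that it is truly neutral, nor that it would behave the same way on any other core in the series.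

On these data alone, it remains open whether an amine or a carboxylic acid in place of fluoro on this aromatic carbon would move the number beyond the scatter.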